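Methoxymethyl in place of cyclopropyl in the series

This account rests on a few compounds, and the source may have more. Where it says the series, first, only, none or still open, it means among the compounds named here.

In a physicochemical assay for lipophilicity, read by HPLC, at pH 7.5 (on this read-out higher numbers stand for higher lipophilicity and lower numbers for lower lipophilicity), compound 2 `CCOc1ccccc1-c1ccc(-c2nc3cnccc3c(NC(C(N)=O)C3CC3)c2C#N)cc1` reads 3, the higher of two numbers, while compound 1 `CCOc1ccccc1-c1ccc(-c2nc3cnccc3c(N[C@H](CC)C(=O)O)c2C#N)cc1` reads 2.1. Compound 3 `CCOc1ccccc1-c1ccc(-c2nc3cnccc3c(NC(COC)C(N)=O)c2C#N)cc1` carries methoxymethyl in place of cyclopropyl on a saturated chain carbon bound to a carbonyl carbon and a nitrogen on an aromatic ring. Among the compounds with values here, the only measured step, a number 0.90 log units higher from compound 1 to compound 2 (beyond the scatter), replaces the whole group on that nitrogen and is a loose guide. Within the data shown here, no measured step isolates this change, so the direction rests on the structure alone. The expected step is a modest fall, a number 0.50 log units lower from compound 2 to compound 3 (beyond the scatter). For compound 3 the estimated value is 2.5, with an expected range of 2.1 to 2.9.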

Compound 3, distribution coefficient: 2.8
For compound 3 the middle estimate is 0.30 log units below the measured one, and the stated range covers the measured number.
By their numbers in this assay, from the lowest: compound 1; then compounds 3 and 2 (each within the scatter of the next).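

In this assay the step of a number 0.20 log units lower from compound 2 to compound 3 (within the scatter) comes with methoxymethyl in place of cyclopropyl on a saturated chain carbon bound to a carbonyl carbon and a nitrogen on an aromatic ring, so this change does not separate the two compounds on this read-out. The step of a number 0.70 log units higher from compound 1 to compound 3 (beyond the scatter) comes with 1-carbamoyl-2-methoxyethyl in place of 1-carboxypropyl on a nitrogen on an aromatic ring, leaving compound 1 apart from both other compounds. No available evidence accounts for these results.

Open, from the compounds shown here alone, is whether a longer chain or an amine on that carbon would stay within the scatter of compound 2. Also open, going by these compounds, is how a carboxylic acid would read with cyclopropyl or methoxymethyl there.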